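Phenyl for methyl on the ring nitrogen of compound 3

This account rests on a few compounds, and the source may have more. Where it says the series, first, only, none or still open, it means among the compounds named here.

Measured so far:
compound 1, `COC(=O)c1c(O)c2ccccc2n(-c2ccccc2)c1=O`, 9.1%
compound 2, `NCCNC(=O)c1c(O)c2ccccc2n(-c2ccccc2)c1=O`, 7.2%
compound 3, `Cn1c(=O)c(C(=O)NCCCCCCN)c(O)c2ccccc21`, 3.1%

In a functional assay, with a stated time of 20 min, tested at 0.1 mM (on this read-out higher numbers stand for a stronger effect at the one concentration tested and lower numbers for a weaker effect), all three compounds give low numbers. Compound 3 has the lowest of the three, but its gap to compound 2 and its gap to compound 1 are both within the scatter, so no order among them can be read from these values. Among the measured compounds shown here, the only step between two compounds that differ in one place is a number 1.9 percentage points lower from compound 1 to compound 2 (within the scatter), and it concerns the group on the carbonyl carbon, not the aromatic nitrogen.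

Compound 4, `NCCCCCCNC(=O)c1c(O)c2ccccc2n(-c2ccccc2)c1=O`, is not yet measured. It differs from compound 3 by phenyl in place of methyl on an aromatic nitrogen. For the measured compounds named here, no measured pair changes this position, so there is no step that bears directly on it; what is known is only that compounds 1 and 2, which carry the phenyl on that nitrogen, sit within the scatter of compound 3. The expected step is therefore a number 2.9 percentage points higher from compound 3 to compound 4 (within the scatter), none beyond the scatter. Compound 4 is estimated at 6%, in the range 0% to 15%.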

Compound 4, a percentage reported as activity, at one concentration (the size of the read-out at that concentration, not a potency): 11.6%
For compound 4 the middle estimate is 5.6 percentage points below the measured one, and the stated range covers the measured number.
By their numbers in this assay, from the lowest: compounds 3, 2, 1 and 4 (each within the scatter of the next).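

In this assay, among the compounds shown here, the change from methyl to phenyl on the aromatic nitrogen, the first direct reading at this position, gives a number 8.5 percentage points higher from compound 3 to compound 4 (within the scatter) and so does not separate the two groups. With the phenyl kept, 4-aminobutyl in place of amino on the chain gives a number 4.4 percentage points higher from compound 2 to compound 4 (within the scatter) and (6-aminohexyl)amino in place of methoxy on the carbonyl carbon gives a number 2.5 percentage points higher from compound 1 to compound 4 (within the scatter) and neither change separates its pair. Nothing shown here offers an explanation for these numbers.

On these data alone, whether a benzyl group on the aromatic nitrogen, or a carboxylic acid in place of the amino group on the chain, would give a step beyond the scatter stays open. These readings come from a single concentration and show only the size of the effect of all four compounds at that concentration.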